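Replacing the 1-ethylpentyl group in a tracheal antagonist series

This account rests on a few compounds, and the source may have more. Where it says the series, first, only, none or still open, it means among the compounds named here.

Three compounds share a core and differ only at the carbonyl side chain. Compound 1 `CCCCC(CC)C(=O)Nc1ccc2ccn(Cc3ccc(C(=O)NS(=O)(=O)c4ccccc4)cc3OC)c2c1` gives 8.6 in a functional assay (trachea) for antagonist activity, with Cavia porcellus as the target; a higher number here means a more potent compound, by a factor of ten per unit of this negative logarithm, a lower number a less potent compound. Compound 2 `CCCCC(CC)C(=O)Nc1ccc2ccn(Cc3ccc(C(=O)C(C#N)S(=O)(=O)c4ccccc4)cc3OC)c2c1` gives 8.1 in this assay, and compound 3 `CCCCC(CC)C(=O)Nc1ccc2ccn(Cc3ccc(C(=O)C(C(=O)OC)S(=O)(=O)c4ccccc4)cc3OC)c2c1` gives 8.5 in this assay. The two measured steps, a number 0.50 log units lower from compound 1 to compound 2 (beyond the scatter) and a number 0.40 log units higher from compound 2 to compound 3 (beyond the scatter), are both modest. Compound 3 stands second highest of the three numbers, within the scatter of compound 1 and beyond the scatter of compound 2.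

Compound 4 `COC(=O)C(C(=O)c1ccc(Cn2ccc3ccc(NC(=O)CC4CCCC4)cc32)c(OC)c1)S(=O)(=O)c1ccccc1` differs from compound 3 at the other end of the molecule: cyclopentylmethyl in place of 1-ethylpentyl on a carbonyl carbon. Among the measured compounds shown here, neither measured step touches this amide carbonyl, so no step bears directly on the change; the data only show that modest changes elsewhere moved this assay by a few tenths. Both groups entering and leaving are saturated hydrocarbons of similar size without donors or acceptors. He therefore expects for compound 4 a step of a number 0.10 log units lower from compound 3 to compound 4 (within the scatter), most likely none beyond the scatter, and estimates compound 4 at 8.4, in the range 7.8 to 9.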

Compound 4, negative logarithm of the antagonist equilibrium constant: 10.1
Estimate against measurement, compound 4: 1.70 log units below, outside the stated range (above it).
By their numbers in this assay, from the lowest: compound 2; then compounds 3 and 1 (each within the scatter of the next); then compound 4.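

The position on this carbonyl carbon proves far more sensitive in this assay than the steps at the other end of the molecule had suggested: cyclopentylmethyl in place of 1-ethylpentyl gives a number 1.60 log units higher from compound 3 to compound 4 (beyond the scatter), a large step. Two saturated hydrocarbon groups, neither with hydrogen-bond donors or acceptors and differing little in heavy atoms, are therefore not interchangeable at this place. No evidence is available to account for this gain.

The compounds shown leave open whether the five-membered ring itself or some other difference between the two groups carries the step, and what a cyclohexylmethyl or a plain cyclopentyl group would give here. They also leave open whether the same change would give a similar step on compound 1 or compound 2.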